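The source may report more compounds than this note shows. Statements on the series, on what has been measured and on what is new or still open speak of the compounds shown alone.

Of the compounds shown here, three built on one shared core have been measured in a functional assay on MIA PaCa-2 cells (Homo sapiens) for inhibition, read by MTT assay, with a stated time of 7 days; on this read-out higher numbers stand for weaker inhibition and lower numbers for stronger inhibition. Compound 1 `CCN(CC)S(=O)(=O)c1ccc(S(=O)(=O)N2CCC[C@@H](C(=O)N3CCS(=O)(=O)CC3)C2)cc1` gives 900 nM. Compound 2 `CCN(CC)S(=O)(=O)c1ccc(S(=O)(=O)N2CCC[C@@H](C(=O)N3CCC(O)CC3)C2)cc1` gives 870 nM. Compound 3 `CCN(CC)S(=O)(=O)c1ccc(S(=O)(=O)N2CCC[C@@H](C(=O)N[C@H]3CC[C@H](OC)CC3)C2)cc1` gives 1350 nM, the highest of the three numbers, though the two steps leading to it, a 1.5-fold higher number from compound 1 to compound 3 (0.18 log units; within the scatter) and a 1.6-fold higher number from compound 2 to compound 3 (0.19 log units; within the scatter), both stay within the scatter, so no ordering among these three can be read from them.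

Compound 4 `CCN(CC)S(=O)(=O)c1ccc(S(=O)(=O)N2CCC[C@@H](C(=O)N3CC[C@@H](OC)C3)C2)cc1` has not yet been measured. It differs from compound 3 at one place: 3-methoxypyrrolidin-1-yl in place of (4-methoxycyclohexyl)amino on a carbonyl carbon. Within the data shown here, the steps that bear on this change are the exchanges of the group on the carbonyl carbon already seen, from compound 1 to compound 3 and from compound 2 to compound 3, each within the scatter. On that basis the expectation for compound 4 in this assay is a step of about a 1.4-fold lower number from compound 3 to compound 4 (0.13 log units; within the scatter), that is, nothing beyond the scatter. Compound 4 is therefore estimated at 1000 nM, with a likely range from 450 nM to 2200 nM.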

Compound 4, half-maximal inhibitory concentration: 3910 nM
Beside the measured number, compound 4's estimate is 3.9-fold (0.59 log units) below it; measured number above the stated range.
By their numbers in this assay, from the lowest: compounds 2, 1 and 3 (each within the scatter of the next); then compound 4.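

Until now, every exchange on this carbonyl carbon stayed within the scatter, so the position could have seemed indifferent to the group placed there. In this assay, among these compounds, 3-methoxypyrrolidin-1-yl is the first group to go beyond the scatter, toward weaker inhibition, with a 2.9-fold higher number from compound 3 to compound 4 (0.46 log units; beyond the scatter) and a 4.5-fold higher number from compound 2 to compound 4 (0.65 log units; beyond the scatter) and a 4.3-fold higher number from compound 1 to compound 4 (0.64 log units; beyond the scatter) so the position does not accept every group equally. Nothing measured here bears on why this group gives the higher number.

The step from compound 3 to compound 4 changes the ring size, the amide hydrogen and the stereocentres together, so the compounds shown cannot tell which of these matters. A 4-methoxypiperidin-1-yl group would keep the six-membered ring without the amide hydrogen, while a (3-methoxycyclopentyl)amino group would keep that hydrogen on a five-membered ring.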